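A few compounds are considered here, and "the series" means these few. Any claim that something is new, unique, unknown or untested is made for them only; others in the source may bear on it.

In a functional assay on MCF7 cells (Homo sapiens) for inhibition, read by sulforhodamine B assay, with a stated time of 48 h (on this read-out higher numbers stand for weaker inhibition of growth and lower numbers for stronger inhibition of growth), compound 1 (`O=C(CCl)NC(=O)Nc1ccc(-c2ccccc2)cc1`) gives 3900 nM and compound 2 (`O=C(CCl)NC(=O)Nc1ccc(Oc2ccccc2)cc1`) gives 4200 nM. Compound 3 (`O=C(CCl)NC(=O)Nc1ccc(I)cc1`) gives 6800 nM, which places it within the scatter of both of the others. Compound 4 (`Cc1ccc(NC(=O)NC(=O)CCl)cc1`) differs from compound 3 by methyl in place of iodo on an aromatic carbon. Among the compounds with values here, no compound measured so far carries methyl at this carbon, so the evidence is indirect. The measured steps that bear on the change swap the group at this same carbon: a 1.7-fold higher number from compound 1 to compound 3 (0.24 log units; within the scatter), a 1.6-fold higher number from compound 2 to compound 3 (0.21 log units; within the scatter) and a 1.1-fold higher number from compound 1 to compound 2 (0.03 log units; within the scatter). All three are small, even though phenyl, phenoxy and iodo are quite different groups. With those steps as the guide, no change beyond the scatter is expected in this assay, and no direction can be firmly called. The expected step is a 1.1-fold higher number from compound 3 to compound 4 (0.04 log units; within the scatter). For compound 4 the estimated value is 7500 nM, with an expected range from 3500 nM to 16000 nM.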

Compound 4, concentration for 50% growth inhibition: 7500 nM
For compound 4 middle estimate and measured number coincide at the digits printed; the range from low to high includes it.
By their numbers in this assay, from the lowest: compounds 1, 2, 3 and 4 (each within the scatter of the next).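

In this assay the group at this carbon can be reduced to methyl, a single heavy atom, and the numbers still stay within the scatter (a 1.1-fold higher number from compound 3 to compound 4 (0.04 log units; within the scatter); a 1.8-fold higher number from compound 2 to compound 4 (0.25 log units; within the scatter); a 1.9-fold higher number from compound 1 to compound 4 (0.28 log units; within the scatter)). Phenyl, phenoxy, iodo and methyl now all lie within the scatter of one another, so among these four compounds the group at this carbon does not separate one compound from another, even at its smallest. Nothing measured here accounts for this insensitivity.

From the compounds shown here alone, whether an amine or a carboxylic acid at this carbon would also stay within the scatter remains open. All four compounds share the rest of the core, so they also leave open what a change there would do, such as an amine in place of the chlorine.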